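Swapping a Benzyl Group for Sulfamoyl at the Aniline Nitrogen

A few compounds are considered here, and "the series" means these few. Any claim that something is new, unique, unknown or untested is made for them only; others in the source may bear on it.

Measured so far:
Compound 1 `O=C(O)c1cc(Cn2cc(-c3ccc(NCc4ccccc4)cc3)nn2)cc(-c2ccccc2C(=O)O)c1` gives 215000 nM in an assay on cells for inhibition of ubiquitin carboxyl-terminal hydrolase isozyme L5 (Homo sapiens), read by fluorescence, with a stated time of 30 min; on this read-out higher numbers stand for weaker inhibition and lower numbers for stronger inhibition.
Compound 2 `Nc1ccc(-c2cn(Cc3cc(C(=O)O)cc(-c4ccc(C(=O)O)cc4)c3)nn2)cc1` gives 285000 nM in this assay.

Among the compounds with values here, only two compounds have been measured, and both give very large numbers, meaning weak inhibition. Compound 1 has the lower of the two numbers, but its gap to compound 2 is within the scatter, so no order between them can be claimed. Within the data shown here, compound 2 also differs from compound 1 in more than one place, so no single step between them is given.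

The unmeasured compound 3 `NS(=O)(=O)Nc1ccc(-c2cn(Cc3cc(C(=O)O)cc(-c4ccccc4C(=O)O)c3)nn2)cc1` is derived from compound 1 by one change: sulfamoyl in place of benzyl on a nitrogen on an aromatic ring. The shared core, the triazole linker and both acid groups are untouched.

Among the measured compounds shown here, with no step between measured compounds to lean on, there is no sign in the data that exchanging the substituent on that nitrogen moves the number in either direction. Compound 1 is already close to the top of the measured range, and compound 2 sits there too, so the expected step of a 1.2-fold higher number from compound 1 to compound 3 (0.07 log units; within the scatter) is none beyond the scatter. Compound 3 is therefore estimated at 250000 nM, with a likely range from 100000 nM to 600000 nM.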

Compound 3, half-maximal inhibitory concentration: 84500 nM
Beside the measured number, compound 3's estimate is 3.0-fold (0.47 log units) above it; the measured number lies below the stated range.
By their numbers in this assay, from the lowest: compound 3; then compounds 1 and 2 (each within the scatter of the next).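

Within the data shown here, the substituent on a nitrogen on an aromatic ring turns out to be a place where the number in this assay can move: sulfamoyl in place of benzyl gives a 2.5-fold lower number from compound 1 to compound 3 (0.41 log units; beyond the scatter), the only step in this set so far that can be read beyond the scatter. The change removes a six-membered aromatic ring of carbon only and brings in a group with fewer heavy atoms, no ring, one hydrogen-bond donor and two hydrogen-bond acceptors, so the benzyl ring is not needed to hold the number at the level of compound 1. Nothing measured here shows which of these differences accounts for the step.

A single step cannot separate the loss of benzyl from the gain of sulfamoyl, and an acetyl or methanesulfonyl group on the same nitrogen would be needed to tell whether the sulfamoyl group itself matters. From the compounds shown here alone, it also remains open whether any change at this nitrogen can go much further, since compound 3 still gives 84500 nM, which is a weak inhibition.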